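Tetrahydroisoquinoline Amide Expected to Stay at Assay Limit

A few compounds are considered here, and "the series" means these few. Any claim that something is new, unique, unknown or untested is made for them only; others in the source may bear on it.

Compound 1 `CS(=O)(=O)c1ccc(C(=O)NCCC(=O)N2CCCCC2)cc1[N+](=O)[O-]` was tested in an assay on isolated protein for inhibition of thyroid hormone receptor alpha (Homo sapiens), read by fluorescence polarization; on this read-out lower numbers stand for stronger inhibition and higher numbers for weaker inhibition. In this assay compound 1 gives > 60000 nM, which is a limit of the assay rather than a number. Compound 2 `CC(C)N(C(=O)C1CCN(C(=O)c2ccc(S(C)(=O)=O)c([N+](=O)[O-])c2)CC1)C(C)C` shares the core of compound 1, and in this assay compound 2 gives > 60000 nM, again a limit. Compound 3 `CN(CC(=O)N1CCc2ccccc2C1)C(=O)c1ccc(S(C)(=O)=O)c([N+](=O)[O-])c1` in this assay gives > 60000 nM, also a limit. All three measured values therefore sit at the limit of > 60000 nM in this assay, at which 3 of the 3 values shown sit, so compound 1 stands level with the others and has no numbered potency of its own. Within the data shown here, with every value a limit, no step between measured compounds can be drawn.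

Compound 4 `CS(=O)(=O)c1ccc(C(=O)NCCC(=O)N2CCc3ccccc3C2)cc1[N+](=O)[O-]` is the unmeasured member. It differs from compound 1 by 1,2,3,4-tetrahydroisoquinolin-2-yl in place of piperidin-1-yl on a carbonyl carbon. Compound 3 already carries a 1,2,3,4-tetrahydroisoquinolin-2-yl group and sits at the limit. The step expected in this assay is a step that the limit leaves unreadable from compound 1 to compound 4, none beyond the scatter. Compound 4 is estimated to give 80000 nM in this assay, within 30000 nM to 200000 nM, most probably reported once more only as a limit.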

Compound 4, half-maximal inhibitory concentration: > 60000 nM
Compound 4: a limit, no number; the forecaster's own chance of this, stated with the estimate: 85%; the middle value lies beyond the limit too.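

Compound 1 and compound 4 are both reported only as limits in this assay, so no step can be read between them: the limit of > 60000 nM in this assay, at which 4 of the 4 values shown sit.

The compounds shown leave open how 1,2,3,4-tetrahydroisoquinolin-2-yl in place of piperidin-1-yl on a carbonyl carbon would act on a numbered potency.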